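A few compounds are considered here, and "the series" means these few. Any claim that something is new, unique, unknown or untested is made for them only; others in the source may bear on it.

Compound 1, `COc1cccc(/C=C/C(=O)/C=C(O)/C=C/c2cccc(OC)c2OC)c1OC`, in a functional assay on MCF7 cells (Homo sapiens) for antiproliferative activity, read by sulforhodamine B assay, with a stated time of 48 h; a higher number here means a weaker inhibitor, a lower number a stronger inhibitor: > 50000 nM, a limit of the assay rather than a number.
Compound 2, `COc1ccc(OC)c(/C=C/C(=O)/C=C(O)/C=C/c2cc(OC)ccc2OC)c1`: > 50000 nM, likewise only a limit of the assay.
Compound 3, `COc1ccc(C=C(C(=O)/C=C/c2cccc(OC)c2OC)C(=O)/C=C/c2cccc(OC)c2OC)cc1OC`: 560 nM.

Compound 3 is thus the only one of the three with a measured number; the other two values sit at the limit of > 50000 nM in this assay, at which 2 of the 3 values shown sit. Compound 4, `COc1cc(OC)c(C=C(C(=O)/C=C/c2cccc(OC)c2OC)C(=O)/C=C/c2cccc(OC)c2OC)c(OC)c1`, has not yet been measured in this assay. It differs from compound 3 in a single place: 2,4,6-trimethoxyphenyl in place of 3,4-dimethoxyphenyl on a double-bonded chain carbon bound to a double-bonded chain carbon. For the measured compounds named here, no pair of measured compounds shows this change, and compounds 1 and 2 differ from compound 3 in more than one place, so no step can be read from them. The expectation is a moderate loss of potency from compound 3 to compound 4, that is a step of a 2.7-fold higher number from compound 3 to compound 4 (0.43 log units; beyond the scatter), beyond the usual scatter but far short of the limit. Compound 4 is therefore estimated at 1500 nM in this assay, with a likely range from 300 nM to 8000 nM.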

Compound 4, half-maximal inhibitory concentration: 720 nM
Beside the measured number, compound 4's estimate is 2.1-fold (0.32 log units) above it, and the stated range covers the measured number.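

In this assay, swapping 3,4-dimethoxyphenyl for 2,4,6-trimethoxyphenyl shows up as a 1.3-fold higher number from compound 3 to compound 4 (0.11 log units; within the scatter) and so leaves the two compounds indistinguishable. For the compounds shown here, this gives the first readable step at this place, on a double-bonded chain carbon bound to a double-bonded chain carbon, and it shows that this position can carry either of these two methoxy-bearing rings with no measurable change in potency. No measurement shown here explains this result.

From the compounds shown here alone, it remains open whether the same holds for a different kind of group at this place, such as a phenyl ring carrying an amine or a carboxylic acid, or a longer chain. Compounds 1 and 2 differ from compound 3 in more than one place, so steps to them cannot be read.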